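Hydrazone aryl swap: difluorophenyl to dihydroxyphenyl

The source may hold more compounds than are shown below. What is called first, only, known or untested is meant among the compounds shown, and "the series" means these compounds.

Compound 1 `CN(C)CCn1cnnc1-c1cc(Oc2ccc(NC(=O)N/N=C/c3ccc(F)cc3Cl)cc2F)ccn1` gives 510 nM in a functional assay on HT-29 cells (Homo sapiens) for cytotoxicity, read by MTT assay, with a stated time of 72 h; on this read-out higher numbers stand for weaker inhibition and lower numbers for stronger inhibition. Within the data shown here, compound 2 `CN(C)CCn1cnnc1-c1cc(Oc2ccc(NC(=O)N/N=C/c3ccc(F)cc3F)cc2F)ccn1` gives 960 nM in the same assay, after the one step measured so far, a 1.9-fold higher number from compound 1 to compound 2 (0.27 log units; within the scatter). Among the measured compounds shown here, on the two numbers at hand, compound 2 is therefore not separated from compound 1 beyond the scatter, and no ordering of the pair can be claimed.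

Compound 3 `CN(C)CCn1cnnc1-c1cc(Oc2ccc(NC(=O)N/N=C/c3ccc(O)cc3O)cc2F)ccn1` differs from compound 2 only in the following exchange: 2,4-dihydroxyphenyl in place of 2,4-difluorophenyl on a carbon with a double bond to nitrogen. For the measured compounds named here, the single measured step is a swap of one halogen for another and does not bear on an exchange of both halogens for hydroxyl groups, so no measured step informs the size or direction of this change. The expectation for compound 3 rests on the value of compound 2 alone, with a wide range to reflect this: the step is estimated at a 1.6-fold higher number from compound 2 to compound 3 (0.19 log units; within the scatter). Compound 3 is therefore expected to give about 1500 nM, with a range from 400 nM to 6000 nM.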

Compound 3, half-maximal inhibitory concentration: 52600 nM
For compound 3 the middle estimate is 35-fold (1.54 log units) below the measured one, outside the stated range (above it).
By their numbers in this assay, from the lowest: compounds 1 and 2 (each within the scatter of the next); then compound 3.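

Among these compounds, on a carbon with a double bond to nitrogen, this is the first aryl exchange that moves the number beyond the scatter in this assay: 2,4-dihydroxyphenyl in place of 2,4-difluorophenyl (a 55-fold higher number from compound 2 to compound 3 (1.74 log units; beyond the scatter)) and in place of 2-chloro-4-fluorophenyl (a 100-fold higher number from compound 1 to compound 3 (2.01 log units; beyond the scatter)). Compound 1 and compound 2 remain within the scatter of each other, while compound 3 stands apart from both, although the exchange leaves the count of 8 heavy atoms unchanged and brings in 2 hydrogen-bond donors and 2 hydrogen-bond acceptors. Nothing at hand explains the size of this step.

Both hydroxyl groups enter together, so the compounds shown do not separate the contribution of each one. Also open, from the compounds shown here alone, is where a monohydroxyphenyl or a 2,4-dimethoxyphenyl group would fall relative to compound 2 and compound 3.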